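Swapping a sec-butyl for a fluorophenyl ring

This account rests on a few compounds, and the source may have more. Where it says the series, first, only, none or still open, it means among the compounds named here.

Measured compounds:
compound 1, `Cc1cc(Br)c(S(C)(=O)=O)cc1C(=O)N=C(N)N`, 12 nM
compound 2, `CCc1cc(C)c(C(=O)N=C(N)N)cc1S(C)(=O)=O`, 4.8 nM
compound 3, `CCC(C)c1cc(C)c(C(=O)N=C(N)N)cc1S(C)(=O)=O`, 8 nM

All three were tested in a functional assay for inhibition of sodium/hydrogen exchanger (Oryctolagus cuniculus); on this read-out lower numbers stand for stronger inhibition and higher numbers for weaker inhibition. On these numbers compound 3 gives the second highest value of the three: compound 1 is its nearest neighbour, with a 1.5-fold lower number from compound 1 to compound 3 (0.18 log units; within the scatter), and compound 2 is furthest from it, with a 1.7-fold higher number from compound 2 to compound 3 (0.22 log units; within the scatter). Neither gap is large enough to count as a real difference.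

Compound 4, `Cc1cc(-c2ccc(F)cc2)c(S(C)(=O)=O)cc1C(=O)N=C(N)N`, keeps the shared core and differs from compound 3 in one place: 4-fluorophenyl in place of sec-butyl on an aromatic carbon. Among the measured compounds shown here, none of the measured steps replaces a chain with a ring at this position, so the evidence is indirect. The steps that do touch this position are small: a 2.5-fold lower number from compound 1 to compound 2 (0.40 log units; beyond the scatter), and a 1.5-fold lower number from compound 1 to compound 3 (0.18 log units; within the scatter). Changing what sits here has so far moved the numbers little, so the expectation for compound 4 is a step no larger than the scatter, no change at the digits printed from compound 3 to compound 4 (within the scatter), with widened bounds because a ring is new to this series.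

Compound 4 is therefore estimated at 8 nM, within a range of 2 nM to 40 nM.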

Compound 4, half-maximal inhibitory concentration: 36 nM
Compound 4: the middle estimate sits 4.5-fold (0.65 log units) below what was measured; the measured number falls inside the stated range.
By their numbers in this assay, from the lowest: compounds 2, 3 and 1 (each within the scatter of the next, the first and the last beyond it); then compound 4.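

In this assay, among the compounds shown here, the group on this aromatic carbon, ortho to a methylsulfonyl group, matters more than the earlier compounds showed: there is a 4.5-fold higher number from compound 3 to compound 4 (0.65 log units; beyond the scatter) and a 7.5-fold higher number from compound 2 to compound 4 (0.88 log units; beyond the scatter) and also a 3.0-fold higher number from compound 1 to compound 4 (0.48 log units; beyond the scatter) in this series. Compound 4 is thus the only compound shown that stands beyond the scatter from all the others, and it is the weakest inhibitor of the four, though each of these steps is modest and compound 4 still gives 36 nM on this read-out. The 4-fluorophenyl group brings both a six-membered aromatic ring and a fluorine in place of the sec-butyl chain, and nothing available here accounts for the higher number.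

The compounds shown cannot separate the ring from the fluorine, so it remains open whether a plain phenyl group would sit with compound 4 or with the other three. From the compounds shown here alone, it also remains open whether a saturated ring such as cyclohexyl, or a 4-methoxyphenyl group, would behave like the sec-butyl chain or like the 4-fluorophenyl group at this position.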